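This account rests on a few compounds, and the source may have more. Where it says the series, first, only, none or still open, it means among the compounds named here.

Measured compounds and values in a functional assay on MCF7 cells (Homo sapiens) for inhibition, read by MTT assay, with a stated time of 72 h; on this read-out lower numbers stand for stronger inhibition of growth and higher numbers for weaker inhibition of growth:

Compound 1, `O=S(=O)(NCCCNCC1COc2ccccc2O1)c1cc(C(F)(F)F)cc(C(F)(F)F)c1`, in this assay gives 2500 nM.
Compound 2, `O=S(=O)(NCCCNCc1ccccc1)c1cc(C(F)(F)F)cc(C(F)(F)F)c1`, in this assay gives 3000 nM.
Compound 3, `O=S(=O)(NCCCNCc1cccc2ccccc12)c1cc(C(F)(F)F)cc(C(F)(F)F)c1`, in this assay gives 1400 nM.

Compound 3 holds the lowest of the three numbers. Its gap to compound 1 is within the scatter, a 1.8-fold lower number from compound 1 to compound 3 (0.25 log units; within the scatter), so no order between these two is claimed; its gap to compound 2 is beyond the scatter, a 2.1-fold lower number from compound 2 to compound 3 (0.33 log units; beyond the scatter), a modest step.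

Compound 4, `O=S(=O)(NCCCNCc1cccc(Cl)c1)c1cc(C(F)(F)F)cc(C(F)(F)F)c1`, is not yet measured. Its difference from compound 3 is 3-chlorophenyl in place of naphthalen-1-yl on a saturated chain carbon bound to an amine nitrogen. Going by the values given here, two measured steps bear on this: a 2.1-fold lower number from compound 2 to compound 3 (0.33 log units; beyond the scatter) shows that a single six-membered aromatic ring in this place gives a higher number than naphthalen-1-yl, and a 1.2-fold higher number from compound 1 to compound 2 (0.08 log units; within the scatter) shows that another single-ring group in the same place sits within the scatter of phenyl. Among the compounds with values here, compound 4 carries one six-membered aromatic ring here, as compound 2 does, with a chlorine added; no measured step tells what the chlorine does.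

The expectation for compound 4 is therefore a number between those of compound 2 and compound 3, with a step of a 1.6-fold higher number from compound 3 to compound 4 (0.20 log units; within the scatter) that stays near the edge of the scatter. Compound 4 is estimated at 2200 nM, in the range 1000 nM to 4500 nM.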

Compound 4, concentration for 50% growth inhibition: 2600 nM
For compound 4 the middle estimate is 1.2-fold (0.07 log units) below the measured one, and the stated range covers the measured number.
By their numbers in this assay, from the lowest: compounds 3, 1, 4 and 2 (each within the scatter of the next, the first and the last beyond it).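

In this assay, the first measured chloro in place of hydrogen on an aromatic carbon, a 1.2-fold lower number from compound 2 to compound 4 (0.06 log units; within the scatter), does not separate the chlorine-bearing ring from plain phenyl. With 3-chlorophenyl in this place, a 1.9-fold higher number from compound 3 to compound 4 (0.27 log units; within the scatter) and a 1.0-fold higher number from compound 1 to compound 4 (0.02 log units; within the scatter) both lie within the scatter, so compound 4 cannot be ordered against either naphthalen-1-yl or 2,3-dihydro-1,4-benzodioxin-2-yl, and the single beyond-scatter gap, between phenyl and naphthalen-1-yl, is not reproduced by this second single-ring group. No measurement that would explain these numbers is available.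

The compounds shown leave open what a carboxylic acid, a pyridine ring or an added amine would give on this saturated chain carbon. Also open, going by these compounds, is whether a longer chain at this place would give a number outside the narrow span seen so far.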